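Swapping a Benzyl Ether for a Carboxymethoxyphenyl Arm

The source may hold more compounds than are shown below. What is called first, only, known or untested is meant among the compounds shown, and "the series" means these compounds.

The compounds share one core, seen in compound 3 `COc1ccc(C(OCc2ccc(C)cc2)c2cccc3ccccc23)c(OC)c1OC`, where a saturated carbon carries a trimethoxyphenyl, a naphthyl and a third, variable arm. In a functional assay on MCF7 cells (Homo sapiens) for inhibition, read by sulforhodamine B assay, with a stated time of 48 h (a lower number here means a stronger inhibitor, a higher number a weaker inhibitor), compound 3 gives 10700 nM, the lowest of the two plain numbers at hand. Compound 1 `COc1ccc(C(OCc2ccccc2)c2cccc3ccccc23)c(OC)c1OC` gives 14100 nM, and the step of a 1.3-fold lower number from compound 1 to compound 3 (0.12 log units; within the scatter) separates them. Compound 2 `COc1ccc(C(c2ccc(OCCO)cc2)c2cccc3ccccc23)c(OC)c1OC` reaches only a limit of the assay, > 20000 nM; this is the limit of > 20000 nM in this assay, at which 1 of the 3 values shown sits. Between compound 2 and compound 3 the step of an at least 1.8-fold lower number from compound 2 to compound 3 (0.27 log units; that floor lies within the scatter) is recorded.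

Compound 4 `COc1ccc(C(c2ccc(OCC(=O)O)cc2)c2cccc3ccccc23)c(OC)c1OC` differs from compound 3 by 4-(carboxymethoxy)phenyl in place of (4-methylbenzyl)oxy on a saturated chain carbon bound to two aromatic carbons. The same kind of swap, a benzyl ether replaced by a phenyl bearing an oxygen-linked side chain, occurs from compound 1 to compound 2, where an at least 1.4-fold higher number from compound 1 to compound 2 (0.15 log units; that floor lies within the scatter). A higher number, quite possibly again a limit, is therefore expected, of a size a 2.4-fold higher number from compound 3 to compound 4 (0.39 log units; beyond the scatter). For compound 4 the estimate is 26000 nM, with a range from 12000 nM to 60000 nM.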

Compound 4, half-maximal inhibitory concentration: > 20000 nM
Compound 4 was reported as a limit; the forecaster's own chance of this, stated with the estimate: 60%; the middle value does not contradict the limit.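

With a carboxy end, the phenyl arm again gives no plain number: compound 4, like compound 2, is a limit, so replacing hydroxymethyl with carboxy on this side chain does not yield a readable value. Against the benzyl ethers, the record gives an at least 1.8-fold higher number from compound 3 to compound 4 (0.27 log units; that floor lies within the scatter) and also an at least 1.4-fold higher number from compound 1 to compound 4 (0.15 log units; that floor lies within the scatter) as floors only, and these alone establish no loss. The step between compound 2 and compound 4 cannot be read, because both stand at the same limit: the limit of > 20000 nM in this assay, at which 2 of the 4 values shown sit.

As far as these compounds go, how far beyond that limit compound 2 and compound 4 truly lie stays open. In this assay, from the compounds shown here alone, it is equally open whether an amine at the end of the side chain, or a longer chain on this phenyl arm, would give a plain number.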